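Moving the methylpiperidine: 3-yl to 4-yl

This account rests on a few compounds, and the source may have more. Where it says the series, first, only, none or still open, it means among the compounds named here.

Compound 1 `CN1CCC(c2ccc3c(c2)oc(=O)n3C(=O)NCCCCc2ccc(F)cc2)CC1` gives 0.5 h
Compound 2 `CC(C)CNC(=O)n1c(=O)oc2cc(C3CCCN(C)C3)ccc21` gives > 1 h

In an ADME assay on microsomes from liver (Mus musculus) for metabolic stability, read by LC-MS, using NADPH, with stated times of 15 min and 60 min, tested at 4.6 uM (a lower number here means that the compound disappears faster, a higher number that the compound lasts longer), compound 2 gives > 1 h as a limit of the assay, not a number. Compound 3 `CC(C)CNC(=O)n1c(=O)oc2cc(C3CCN(C)CC3)ccc21` follows from 1-methylpiperidin-4-yl in place of 1-methylpiperidin-3-yl on an aromatic carbon with 1-methylpiperidin-4-yl in place of 1-methylpiperidin-3-yl on an aromatic carbon. Among the measured compounds shown here, no measured pair isolates this change. Compound 1 also carries 1-methylpiperidin-4-yl, with a different chain, and in this assay compound 1 gives 0.5 h as a number. On that basis, only a small downward move or none beyond the scatter is expected, with a number no higher from compound 2 to compound 3 (the limit leaves the size open) as the expected step. Compound 3 is estimated at 1 h in this assay with a range of 0.5 h to 2 h as expected bounds.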

Compound 3, half-life: > 1 h
Compound 3 gave a limit, no number; the forecaster's own chance of this, stated with the estimate: 50%; the middle value sits exactly at the limit.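

In this assay compound 3 gives > 1 h, a limit and not a number. The step between 1-methylpiperidin-3-yl and 1-methylpiperidin-4-yl cannot be read because both values are limits: the limit of > 1 h in this assay, at which 2 of the 3 values shown sit.

Among the compounds shown here, with 1-methylpiperidin-4-yl held in place, isopropyl in place of 3-(4-fluorophenyl)propyl gives an at least 2.0-fold higher number from compound 1 to compound 3 (0.30 log units; that floor lies within the scatter), the first reading of this chain change. From the compounds shown here alone, whether the two piperidine attachments differ at all remains open, as does the true size of the chain step. Also open, going by these compounds, is how a piperidine without the methyl group, or a morpholine, would read at this place on the shared core.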